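From methoxy to propoxy: compound 3 awaits its measurement

The compounds below may be only part of what the source reports. "The series", "measured", "known", "first", "only" and "open" are said of these compounds alone.

Measured in an ADME assay on RAW264.7 cells (Mus musculus) for cytotoxicity, read by MTT assay, with a stated time of 24 h, in the absence of a further agent; on this read-out higher numbers stand for weaker inhibition and lower numbers for stronger inhibition:
compound 1 `O=C1OC(Cc2nc(-c3ccc(-c4ccccc4)cc3)no2)c2ccccc21`: > 40000 nM
compound 2 `COc1ccc(C(O)C2OC(=O)c3c(OC)cc(OC)cc32)cc1`: > 40000 nM

Compound 2 stands at > 40000 nM, which is a limit of this assay and not a number. Among the measured compounds shown here, the same holds across the series so far, with the limit of > 40000 nM in this assay, at which 2 of the 2 values shown sit. Compound 3 `CCCOc1ccc(C(O)C2OC(=O)c3c(OC)cc(OC)cc32)cc1` turns methoxy into propoxy, with ethyl in place of hydrogen on a saturated chain carbon bound to an oxygen on an aromatic ring. For the measured compounds named here, no measured step shows the effect of such a change. No shift beyond the scatter is expected in this assay, and the estimated step is a number no higher from compound 2 to compound 3 (the limit leaves the size open). For compound 3 the expected value is 40000 nM, within an estimated range from 20000 nM to 80000 nM.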

Compound 3, half-maximal inhibitory concentration: > 40000 nM
Compound 3 ended at the assay's limit; the forecaster's own chance of this, stated with the estimate: 75%; the middle value sits exactly at the limit.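

Compound 2 and compound 3 both stand at a limit of this assay, not at a number, and no step can be read between them. Whether going from methoxy to propoxy changes the read-out at all stays open, and the compounds shown give no number to compare: the limit of > 40000 nM in this assay, at which 3 of the 3 values shown sit.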